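The source may report more compounds than this note shows. Statements on the series, on what has been measured and on what is new or still open speak of the compounds shown alone.

In a functional assay on the whole organism for antagonist activity, with Mus musculus as the target (on this read-out higher numbers stand for an effect only at larger amounts of compound and lower numbers for an effect already at smaller amounts), compound 1 `CC(=O)NCC#CCn1ccnc1` gives > 100 mg/kg, which is a limit and not a number. Compound 2 `CC(=O)N(C)CC#CCn1ccnc1` gives > 100 mg/kg, also a limit. Compound 3 `CC(=O)N(C)CC#CCn1cncc1C` gives 6.6 mg/kg. Compound 4 `CN(C)C(=O)N(C)CC#CCn1ccnc1` changes compound 2 by placing dimethylamino in place of methyl on a carbonyl carbon, turning acetyl into dimethylcarbamoyl: dimethylamino in place of methyl on a carbonyl carbon. Two measured steps offer only indirect guidance. One is a step that the two limits leave unreadable from compound 1 to compound 2, with methyl in place of hydrogen on an amide-type nitrogen. The other is an at least 15-fold lower number from compound 2 to compound 3 (1.18 log units; beyond the scatter), with methyl in place of hydrogen on an aromatic carbon. Neither changes the group on the carbonyl carbon, so no large step is expected. The expected result is a number no higher from compound 2 to compound 4 (the limit leaves the size open), with no clear direction. The estimate for compound 4 is 100 mg/kg, within an expected range of 30 mg/kg to 300 mg/kg.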

Compound 4, dose for half-maximal effect: 11.8 mg/kg
Estimate against measurement, compound 4: 8.5-fold (0.93 log units) above; measured number outside the range, below it.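

In this assay, turning acetyl into dimethylcarbamoyl gives an at least 8.4-fold lower number from compound 2 to compound 4 (0.92 log units; beyond the scatter). Earlier, only methyl in place of hydrogen on an aromatic carbon had brought a measurable number; the group on the carbonyl carbon can now do this too, without that methyl. Compound 2 has only a limit, so the full size of this step cannot be read: the limit of > 100 mg/kg in this assay, at which 2 of the 4 values shown sit.

Going by these compounds, it remains open whether methoxy or diethylamino on the carbonyl carbon would serve as well as dimethylamino. On these data alone, it is also open how dimethylamino would behave together with the methyl on the aromatic carbon.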